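Propyl ketone analogue of a thienyl dihydropyrimidinone

The source may report more compounds than this note shows. Statements on the series, on what has been measured and on what is new or still open speak of the compounds shown alone.

Measured so far:
Compound 1, `CC1=C(C(=O)OC(C)(C)C)C(c2cccs2)NC(=O)N1`: 26%
Compound 2, `CC1=C(C(=O)C2CC2)C(c2cccs2)NC(=O)N1`: 1%

In an assay on membranes from CHO cells for displacement of a labelled ligand from adenosine receptor A1 (Homo sapiens), read by scintillation counting, with a stated time of 60 min, tested at 1 uM (on this read-out lower numbers stand for less inhibition and higher numbers for more inhibition at the one concentration tested (going by the name of the read-out)), compound 1 gives 26%, while compound 2 gives 1%, the lowest of the two numbers. Within the data shown here, the single measured step, a number 25 percentage points lower from compound 1 to compound 2 (beyond the scatter), changes the group on the carbonyl carbon and lowers the read-out beyond the scatter.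

Compound 3, `CCCC(=O)C1=C(C)NC(=O)NC1c1cccs1`, has not been measured. It differs from compound 2 by propyl in place of cyclopropyl on a carbonyl carbon. No measured step concerns the swap of a cyclopropyl for a propyl, so the only guide is that compound 2 already stands at the bottom of the shown numbers in this assay. Little room for a further fall remains, and nothing shown points to a rise. Compound 3 is therefore expected to stay close to compound 2, with a number 3 percentage points higher from compound 2 to compound 3 (within the scatter), a step not beyond the scatter. The estimate for compound 3 in this assay is 4%, within -8% to 18%.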

Compound 3, a percentage reported as inhibition, at one concentration (the size of the read-out at that concentration, not a potency): 2%
Beside the measured number, compound 3's estimate is 2 percentage points above it, within the range that was stated.
By their numbers in this assay, from the lowest: compounds 2 and 3 (each within the scatter of the next); then compound 1.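

With propyl in place of cyclopropyl on a carbonyl carbon, this assay shows a number 1 percentage points higher from compound 2 to compound 3 (within the scatter), so at this position the three-membered ring and the open chain cannot be told apart. The other new step, a number 24 percentage points lower from compound 1 to compound 3 (beyond the scatter), shows that the loss seen when tert-butoxy gave way to cyclopropyl is not tied to cyclopropyl, since it also appears with propyl. Nothing given here accounts for the loss or for the likeness of the two ketones.

Going by these compounds, it remains open whether the read-out would be kept by a smaller ester group such as methoxy or ethoxy, or by an amine on the same carbonyl carbon. On these data alone, it is also open whether the oxygen or the tert-butyl part of tert-butoxy matters more, and a tert-butyl ketone would bear on that.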